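The source may report more compounds than this note shows. Statements on the series, on what has been measured and on what is new or still open speak of the compounds shown alone.

In a functional assay on ileum (Cavia porcellus) for antagonist activity (on this read-out higher numbers stand for weaker inhibition and lower numbers for stronger inhibition), three compounds sharing one core have been read. Among the compounds with values here, compound 1 `CC(=O)c1ccc(OCCCOc2ccc3c(O)c([N+](=O)[O-])c(=O)oc3c2)cc1` gives 6100 nM, the only true number among them. Compound 2 `COC(=O)c1ccc(OCCCOc2ccc3c(O)c([N+](=O)[O-])c(=O)oc3c2)cc1` is reported only as a limit, > 10000 nM. From the compounds shown here alone, compound 3 `O=C(O)c1ccc(OCCCOc2ccc3c(O)c([N+](=O)[O-])c(=O)oc3c2)cc1` is likewise only a limit, > 20000 nM, so its exact standing is unknown.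

Compound 4 `Cc1ccc(OCCCOc2ccc3c(O)c([N+](=O)[O-])c(=O)oc3c2)cc1` has methyl in place of carboxy on an aromatic carbon, para to a large group (methyl in place of carboxy on an aromatic carbon). Within the data shown here, no measured step makes this exact change. The nearest evidence is the move from methyl to hydroxy on a carbonyl carbon, which gave an at least 3.2-fold higher number from compound 1 to compound 3 (0.51 log units; beyond the scatter). Methyl to methoxy there gave an at least 1.6-fold higher number from compound 1 to compound 2 (0.21 log units; that floor lies within the scatter), and the remaining pair shows a step that the two limits leave unreadable from compound 2 to compound 3.

Losing the carboxy group is therefore expected to lower the number, with compound 4 landing near compound 1 at 6100 nM. The expected step is an at least 3.3-fold lower number from compound 3 to compound 4 (0.52 log units; beyond the scatter). Compound 4 is estimated at 6000 nM, with an expected range from 1500 nM to 20000 nM.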

Compound 4, half-maximal inhibitory concentration: 4500 nM
The estimate for compound 4 lay 1.3-fold (0.12 log units) above the measured number; low and high end bracket the measured number.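

In this assay, methyl on this aromatic carbon gives an at least 4.4-fold lower number from compound 3 to compound 4 (0.64 log units; beyond the scatter) and an at least 2.2-fold lower number from compound 2 to compound 4 (0.34 log units; beyond the scatter), while against acetyl it gives a 1.4-fold lower number from compound 1 to compound 4 (0.13 log units; within the scatter). A carbonyl at this position is therefore not needed for the level of compound 1, since compound 4 lacks one and still reads alongside it, yet the carbonyl-bearing compound 2 and compound 3 show that such groups do not all behave alike. Compound 2 and compound 3 are both limits and not numbers, so those two steps are floors only, and the higher limit is this one: the limit of > 20000 nM in this assay, at which 1 of the 4 values shown sits.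

From the compounds shown here alone, how far these two steps truly reach remains unknown. Going by these compounds, it is also open whether an amine, an amide or a longer chain on the same aromatic carbon would read with compound 1 and compound 4 or with compound 2 and compound 3.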